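This account rests on a few compounds, and the source may have more. Where it says the series, first, only, none or still open, it means among the compounds named here.

Measured so far:
- Compound 1, `CC(C)=CCC[C@H](C)c1ccc(C)c(CNCC2CCNCC2)c1O`: 18300 nM
- Compound 2, `CCOC(CCNCc1c(C)ccc([C@@H](C)CCC=C(C)C)c1O)OCC`: 14900 nM

Both numbers come from a functional assay on MDA-MB-231 cells (Homo sapiens) for inhibition, read by MTT assay, with a stated time of 72 h; a lower number here means a stronger inhibitor, a higher number a weaker inhibitor. Compound 1 stands as the highest of the two numbers; its nearest neighbour is compound 2, and the step of a 1.2-fold lower number from compound 1 to compound 2 (0.09 log units; within the scatter) is within the scatter, so the two cannot be told apart. That one step swaps 2,2-diethoxyethyl for piperidin-4-yl on a saturated chain carbon bound to an amine nitrogen, and it changed little.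

Compound 3, `CC(C)=CCC[C@H](C)c1ccc(C)c(CO)c1O`, has not yet been tested in this assay. It differs from compound 1 as follows:
hydroxy in place of ((piperidin-4-yl)methyl)amino on a saturated chain carbon bound to an aromatic carbon

Going by the values given here, the only measured step touches the same region of the molecule as this change, since it alters the group carried by the amine nitrogen, but it does not remove the whole ((piperidin-4-yl)methyl)amino unit as the step to compound 3 does. That one step, a 1.2-fold lower number from compound 1 to compound 2 (0.09 log units; within the scatter), was within the scatter, which suggests the shared core of compound 1 and compound 2 carries most of the weak activity seen. On that basis compound 3 is expected to sit near compound 1, with the step of a 1.2-fold higher number from compound 1 to compound 3 (0.08 log units; within the scatter) expected to stay within or only modestly beyond the scatter. The estimate for compound 3 is 22000 nM, in a range from 7000 nM to 70000 nM.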

Compound 3, half-maximal inhibitory concentration: 22200 nM
Estimate against measurement, compound 3: 1.0-fold (0.00 log units) below; the measured number falls inside the stated range.
By their numbers in this assay, from the lowest: compounds 2, 1 and 3 (each within the scatter of the next).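

The step to compound 3 goes much further than the earlier swap on the amine nitrogen. The whole ((piperidin-4-yl)methyl)amino unit, with 8 heavy atoms that include both nitrogens and one six-membered non-aromatic ring, gives way to a hydroxy of 1 heavy atom on the saturated chain carbon bound to an aromatic carbon. Even so, this assay shows a 1.2-fold higher number from compound 1 to compound 3 (0.08 log units; within the scatter) and the two compounds cannot be told apart, so the weak activity of compound 1 does not depend on the ring or the nitrogens of this unit. No measured evidence is available to explain this result.

On these data alone, it remains open whether any other group at this place, such as a carboxylic acid or a simple primary amine, would give a number beyond the scatter of compound 1 in either direction. As far as these compounds go, all three compounds keep the shared core, and the effect of altering that core, for example by replacing the unsaturated side chain with a shorter saturated chain, remains unknown.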